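A few compounds are considered here, and "the series" means these few. Any claim that something is new, unique, unknown or untested is made for them only; others in the source may bear on it.

Measured in a functional assay on MDA-MB-231 cells (Homo sapiens) for antiproliferative activity, read by MTT assay, with a stated time of 72 h; on this read-out higher numbers stand for weaker inhibition and lower numbers for stronger inhibition:
- compound 1 `CC(C)(C)c1ccc(OCCCON2C(N)=NC(N)=NC23CCSCC3)cc1`: 1 nM
- compound 2 `NC1=NC2(CCSCC2)N(OCCCOc2cccc(Cl)c2)C(N)=N1`: 130 nM
- compound 3 `NC1=NC2(CCSCC2)N(OCCCOc2cccc(Cl)c2Cl)C(N)=N1`: 1 nM

Compound 3, at 1 nM, is level with compound 1, and these two share the lowest number of the three. Compound 2 lies far higher, at 130 nM.

The next compound is compound 4 `NC1=NC2(CCSCC2)N(OCCCOc2ccc(Cl)cc2)C(N)=N1`, and the change is 4-chlorophenyl in place of 2,3-dichlorophenyl on an oxygen on a saturated carbon.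

Going by the values given here, only one measured step bears on this change. Adding a chloro in place of hydrogen on an aromatic carbon gave a 130-fold lower number from compound 2 to compound 3 (2.11 log units; beyond the scatter), which is a large step. Compound 4 gives up a chloro relative to compound 3, so a move towards a higher number is expected. The chloro also sits elsewhere on the ring, and the data do not show what that does, so only part of that large step is expected to return.

The expected change is a 15-fold higher number from compound 3 to compound 4 (1.18 log units; beyond the scatter).

For compound 4 the estimated value is 15 nM, with an expected range from 1.5 nM to 150 nM.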

Compound 4, half-maximal inhibitory concentration: 350 nM
Beside the measured number, compound 4's estimate is 23-fold (1.37 log units) below it; the measured number lies above the stated range.
By their numbers in this assay, from the lowest: compounds 1 and 3 (each within the scatter of the next); then compound 2; then compound 4.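

Going by these compounds alone, the pattern of chloro groups on this aryl ring matters more than the earlier compounds could show: the change to 4-chlorophenyl gave a 350-fold higher number from compound 3 to compound 4 (2.54 log units; beyond the scatter) and took compound 4 above even compound 2, so it lost more than the single chloro step had gained. Exchanging 3-chlorophenyl for 4-chlorophenyl gave a far smaller change, a 2.7-fold higher number from compound 2 to compound 4 (0.43 log units; beyond the scatter) and neither compound with a single chloro comes near compound 3. The group on the ring also counts, since chloro in place of tert-butyl on an aromatic carbon gave a 350-fold higher number from compound 1 to compound 4 (2.54 log units; beyond the scatter) in a pair that differs in that place alone.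

The compounds shown leave open what an unsubstituted phenyl, a 2-chlorophenyl or a 3,4-dichlorophenyl group would give. No measurement shown accounts for these differences in size.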